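From a limit of the assay to an expected value

The source may report more compounds than this note shows. Statements on the series, on what has been measured and on what is new or still open speak of the compounds shown alone.

In a functional assay on HeLa cells (Homo sapiens) for cytotoxicity, read by MTT assay (on this read-out lower numbers stand for stronger inhibition and higher numbers for weaker inhibition), compound 1 (`CC(C)=CC[C@@H](OC(=O)CCO)C1=CC(=O)c2c(O)ccc(O)c2C1=O`) gives 67600 nM and compound 2 (`CCCC(CC(=O)O[C@H](CC=C(C)C)C1=CC(=O)c2c(O)ccc(O)c2C1=O)OC(C)=O`) gives 51200 nM in the same test. Compound 3 (`CC(C)=CC[C@@H](OC(=O)C1CCCCO1)C1=CC(=O)c2c(O)ccc(O)c2C1=O`) reads > 100000 nM here, which is a limit and not a number. Compound 4 (`CC(C)=CC[C@@H](OC(=O)CC(C)(O)c1ccccc1)C1=CC(=O)c2c(O)ccc(O)c2C1=O`) carries 2-hydroxy-2-phenylpropyl in place of oxan-2-yl on a carbonyl carbon. The measured steps that bear on this change are small: (an at least 1.4-fold higher number from compound 1 to compound 3 (0.17 log units; that floor lies within the scatter)) and (an at least 1.9-fold higher number from compound 2 to compound 3 (0.29 log units; that floor lies within the scatter)) have floors within the scatter, and (a 1.3-fold lower number from compound 1 to compound 2 (0.12 log units; within the scatter)) lies within it too. The expected step (an at least 1.8-fold lower number from compound 3 to compound 4 (0.25 log units; that floor lies within the scatter)) is therefore a lower number, of similar size to those. For compound 4 the estimate is 55000 nM (expected range 20000 nM to 100000 nM).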

Compound 4, half-maximal inhibitory concentration: 85700 nM
Compound 4: middle estimate off by 1.6-fold (0.19 log units), on the low side; the range from low to high includes it.
By their numbers in this assay, from the lowest: compounds 2, 1 and 4 (each within the scatter of the next). At a limit, above all of these: compound 3.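

In this assay the 2-hydroxy-2-phenylpropyl group brings a six-membered aromatic ring of carbon only onto this carbonyl carbon, yet the number stays within the scatter of both earlier measured values (a 1.3-fold higher number from compound 1 to compound 4 (0.10 log units; within the scatter); a 1.7-fold higher number from compound 2 to compound 4 (0.22 log units; within the scatter)). Compound 3 reads > 100000 nM and that is a limit of the assay, not a number. The remaining step is therefore only a floor (an at least 1.1-fold lower number from compound 3 to compound 4 (0.06 log units; that floor lies within the scatter)), because one end of it sits at the limit: the limit of > 100000 nM in this assay, at which 1 of the 4 values shown sits. On these data alone, whether an amine or a carboxylic acid on this chain would move the number beyond the scatter stays open.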